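Methoxy for Fluoro Tested on a Second Benzyl Core

The source may hold more compounds than are shown below. What is called first, only, known or untested is meant among the compounds shown, and "the series" means these compounds.

Compound 1 `Cc1ccc(Cn2c(/C=C3\SC(=S)N(CC(=O)O)C3=O)nc3cc(F)ccc32)cc1` and compound 2 `COc1ccc2c(c1)nc(/C=C1\SC(=S)N(CC(=O)O)C1=O)n2Cc1ccc(C)cc1` share one core and differ by methoxy in place of fluoro on an aromatic carbon. In a functional assay on HL-60 cells (Homo sapiens) for cytotoxicity, read by MTT assay, with a stated time of 48 h (on this read-out higher numbers stand for weaker inhibition and lower numbers for stronger inhibition), compound 1 gives 1170 nM and compound 2 gives 770 nM, a step of a 1.5-fold lower number from compound 1 to compound 2 (0.18 log units; within the scatter). Compound 3 `O=C(O)CN1C(=O)/C(=C/c2nc3cc(F)ccc3n2Cc2ccccc2F)SC1=S` stands on a different core, set apart from compound 1 by 2-fluorophenyl in place of 4-methylphenyl on a saturated chain carbon bound to an aromatic nitrogen, with a step of an at least 42-fold higher number from compound 1 to compound 3 (1.63 log units; beyond the scatter). In this assay compound 3 reaches only the limit of the assay, > 50000 nM, which is not a number. Compound 4 `COc1ccc2c(c1)nc(/C=C1\SC(=S)N(CC(=O)O)C1=O)n2Cc1ccccc1F` has not been measured; it differs from compound 3 by methoxy in place of fluoro on an aromatic carbon, the same change that separates compound 1 from compound 2. Because the earlier step of a 1.5-fold lower number from compound 1 to compound 2 (0.18 log units; within the scatter) stayed within the scatter, compound 4 is expected to show a step that the limit leaves unreadable from compound 3 to compound 4. Compound 4 is therefore estimated near 60000 nM, most likely again only as a limit.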

Compound 4, half-maximal inhibitory concentration: 3410 nM
Beside the measured number, compound 4's estimate is 18-fold (1.25 log units) above it; the whole stated range lies above it.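

In this assay, methoxy in place of fluoro gives an at least 14-fold lower number from compound 3 to compound 4 (1.16 log units; beyond the scatter), so this change does not carry over at one size from one core to the other: the same change on two cores in this assay, a 1.5-fold lower number (0.18 log units; within the scatter) from compound 1 to compound 2 and an at least 14-fold lower number (1.16 log units; beyond the scatter) from compound 3 to compound 4, at least 9.6-fold (0.98 log units) apart, beyond the scatter of two such steps

The swap of 2-fluorophenyl for 4-methylphenyl also depends on its setting, here giving a 4.4-fold higher number from compound 2 to compound 4 (0.65 log units; beyond the scatter): the same change on two cores in this assay, an at least 42-fold higher number (1.63 log units; beyond the scatter) from compound 1 to compound 3 and a 4.4-fold higher number (0.65 log units; beyond the scatter) from compound 2 to compound 4, at least 9.6-fold (0.98 log units) apart, beyond the scatter of two such steps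

Compound 3 gives > 50000 nM, a limit and not a number; the true size of both gaps therefore stays unknown, and these two pairs give neither a general rule nor a cause.

Still open, going by these compounds, is how another group on that aromatic carbon, such as an amine or a hydroxyl, would behave on these two cores.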